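Series notes: trifluoromethyl in place of amino

This account rests on a few compounds, and the source may have more. Where it says the series, first, only, none or still open, it means among the compounds named here.

Measured so far:
compound 1 `COc1ccc(S(=O)(=O)c2nc3ccccc3nc2Nc2cc(OC)cc(OC)c2)cc1`: 12700 nM in a functional assay on A549 cells (Homo sapiens) for cytotoxicity, read by MTT assay, with a stated time of 72 h; a higher number here means a weaker inhibitor, a lower number a stronger inhibitor
compound 2 `COc1ccc(S(=O)(=O)c2nc3ccccc3nc2Nc2ccc(N)cc2)cc1`: 2990 nM in this assay

Going by the values given here, compound 2 holds the lowest number of the two in this assay; the only neighbour is compound 1, separated by a 4.2-fold lower number from compound 1 to compound 2 (0.63 log units; beyond the scatter). Compound 3 `COc1ccc(S(=O)(=O)c2nc3ccccc3nc2Nc2ccc(C(F)(F)F)cc2)cc1` differs from compound 2 by trifluoromethyl in place of amino on an aromatic carbon. Among the compounds with values here, no measured step covers this exchange. Within the data shown here, the single step recorded, a 4.2-fold lower number from compound 1 to compound 2 (0.63 log units; beyond the scatter), shows only that the aryl group on that nitrogen moves the number by a modest amount, with a different pair of groups. For compound 3 a step of a 2.0-fold higher number from compound 2 to compound 3 (0.30 log units; within the scatter) toward a higher number is expected, with wide uncertainty. The estimate for compound 3 is 6000 nM, between 2000 nM and 18000 nM.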

Compound 3, half-maximal inhibitory concentration: 4810 nM
Beside the measured number, compound 3's estimate is 1.2-fold (0.10 log units) above it; measured number inside the range.
By their numbers in this assay, from the lowest: compounds 2 and 3 (each within the scatter of the next); then compound 1.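

In this assay the exchange on this aromatic carbon, para to a large group, gives a 1.6-fold higher number from compound 2 to compound 3 (0.21 log units; within the scatter) and so stays within the scatter: amino, with its hydrogen-bond donor, can give way to trifluoromethyl, which has none, without a readable change. Against the 3,5-dimethoxyphenyl group, a 2.6-fold lower number from compound 1 to compound 3 (0.42 log units; beyond the scatter) is still seen, so the difference from compound 1 does not depend on amino alone. Nothing available explains these numbers. Open, from the compounds shown here alone, is whether a carboxylic acid, a nitrile or a longer chain on this carbon would read the same.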